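A few compounds are considered here, and "the series" means these few. Any claim that something is new, unique, unknown or untested is made for them only; others in the source may bear on it.

Compound 1, `C[C@H]1[C@H](NCc2cncs2)C[C@H]2C[C@@H]1C2(C)C`: > 100000 nM
Compound 2, `CCCc1ccsc1CN[C@@H]1C[C@H]2C[C@@H]([C@H]1C)C2(C)C`: 50000 nM
Compound 3, `C=C(C)c1csc(CN[C@@H]2C[C@H]3C[C@@H]([C@H]2C)C3(C)C)c1`: 25000 nM

The three measured compounds share a common core and differ in the group carried on the amine. In an ADME assay on MDCK cells (Canis lupus familiaris) for cytotoxicity, read by microscopy, with a stated time of 48 h (a lower number here means that less compound is tolerated, a higher number that more compound is tolerated), compound 2 gives 50000 nM. Compound 1 reaches only a limit of this assay, > 100000 nM. Compound 3 gives 25000 nM in this assay. Of the two plain numbers, compound 2 holds the higher one, but its gap to compound 3 lies within the scatter, so the two cannot be told apart; the remaining value is a limit.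

Compound 4, `C[C@H]1[C@H](NCc2sccc2C2CCCC2)C[C@H]2C[C@@H]1C2(C)C`, has not yet been measured in this assay. It differs from compound 2 in one place: cyclopentyl in place of propyl on an aromatic carbon. Among the measured compounds shown here, no step between measured compounds involves this change, so the expectation rests on compound 2 alone. The step is expected to be small, at most a slight move toward a lower number and not beyond the scatter, namely a 1.4-fold lower number from compound 2 to compound 4 (0.15 log units; within the scatter). Compound 4 is therefore estimated at 35000 nM in this assay, between 12000 nM and 100000 nM.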

Compound 4, minimum cytotoxic concentration: 12500 nM
The estimate for compound 4 lay 2.8-fold (0.45 log units) above the measured number, within the range that was stated.
By their numbers in this assay, from the lowest: compounds 4, 3 and 2 (each within the scatter of the next, the first and the last beyond it). At a limit, above all of these: compound 1.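

In this assay, the group on this aromatic carbon, two ring bonds from the ring sulfur, matters: cyclopentyl in place of propyl brings a 4.0-fold lower number from compound 2 to compound 4 (0.60 log units; beyond the scatter). Among the compounds shown here, this is the first step between measured compounds that differ in one place, so the earlier compounds could not show that a change at this position alone can move the number beyond the scatter. Nothing in the data shown gives a measured property that accounts for this step.

This single pair cannot separate the effect of the cyclopentyl ring from that of the added carbon atoms, and a branched chain such as isopropyl would be needed to tell them apart. On these data alone, how an amine, a carboxylic acid or a longer chain at this position would read in this assay also remains open.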